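Methyl to Methoxy on a Second Arrangement of the Core

The source may report more compounds than this note shows. Statements on the series, on what has been measured and on what is new or still open speak of the compounds shown alone.

Compound 1 `Cc1ccccc1NC(=S)N1CCc2c(sc(NC(=O)c3ccccc3Cl)c2C(N)=O)C1` and compound 2 `COc1ccccc1NC(=S)N1CCc2c(sc(NC(=O)c3ccccc3Cl)c2C(N)=O)C1` share one core, and in a functional assay on MKN-74 cells (Homo sapiens) for antiproliferative activity, with a stated time of 24 h (a lower number here means a stronger inhibitor, a higher number a weaker inhibitor), compound 1 gives 11700 nM while compound 2 gives 35200 nM. The step of a 3.0-fold higher number from compound 1 to compound 2 (0.48 log units; beyond the scatter) corresponds to the change (methoxy in place of methyl on an aromatic carbon). Compound 3 `Cc1ccccc1C(=O)Nc1sc2c(c1C(N)=O)CCN(C(=S)Nc1ccccc1Cl)C2` is built from the same atoms as compound 1, joined differently; the difference between the two cores is not broken down here. In this assay compound 3 gives 11000 nM, a number within the scatter of that of compound 1 and beyond the scatter of that of compound 2. Compound 4 `COc1ccccc1C(=O)Nc1sc2c(c1C(N)=O)CCN(C(=S)Nc1ccccc1Cl)C2` has not been measured in this assay. It differs from compound 3 by methoxy in place of methyl on an aromatic carbon, the same change as from compound 1 to compound 2, set on the core of compound 3. Within the data shown here, compound 4 is expected to show a 2.3-fold higher number from compound 3 to compound 4 (0.36 log units; beyond the scatter), a step of about the size seen in compound 2, because the only measured instance of this change is a 3.0-fold higher number from compound 1 to compound 2 (0.48 log units; beyond the scatter). For compound 4 the estimate is 25000 nM, with a range from 10000 nM to 60000 nM.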

Compound 4, half-maximal inhibitory concentration: 20500 nM
For compound 4 the middle estimate is 1.2-fold (0.09 log units) above the measured one, and the stated range covers the measured number.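

In this assay, methoxy in place of methyl on the core of compound 3 gives a 1.9-fold higher number from compound 3 to compound 4 (0.27 log units; within the scatter), so on this core the step alone cannot be told apart from the scatter of repeated measurements. Set beside the step on the core of compound 1, it does not differ measurably: the same change on two cores in this assay, a 3.0-fold higher number (0.48 log units; beyond the scatter) from compound 1 to compound 2 and a 1.9-fold higher number (0.27 log units; within the scatter) from compound 3 to compound 4, 1.6-fold (0.21 log units) apart, within the scatter of two such steps. Among these compounds, the data therefore fit a single step size for this change on both cores, but they rest on one pair per core, only one of the two steps lies beyond the scatter, and they do not show that the change would carry to any further core or to any other assay.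

The compounds shown leave open how an ethoxy, a hydroxyl or an amine would behave on the same aromatic carbon, as every pair here holds only methyl and methoxy there. They also leave open whether the step would look the same on a core carrying a carboxylic acid or a longer chain.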